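Ortho-substituted benzyl variant in the sigma-1 series

A few compounds are considered here, and "the series" means these few. Any claim that something is new, unique, unknown or untested is made for them only; others in the source may bear on it.

Measured compounds:
compound 1 `O=c1oc2ccccc2n1CC1CCN(Cc2ccccc2Cl)CC1`, 61 nM
compound 2 `O=c1oc2ccccc2n1CC1CCN(Cc2ccc(Cl)cc2)CC1`, 0.1 nM
compound 3 `O=c1oc2ccccc2n1CC1CCN(Cc2ccc(F)cc2)CC1`, 3.9 nM

In an assay on membranes from liver for displacement of a labelled ligand from Sigma non-opioid intracellular receptor 1 (Rattus norvegicus) (a lower number here means a stronger inhibitor, a higher number a weaker inhibitor), compound 3 gives 3.9 nM, the second highest of the three numbers: compound 1 is the nearest, a 16-fold lower number from compound 1 to compound 3 (1.19 log units; beyond the scatter), and compound 2 is the furthest, a 39-fold higher number from compound 2 to compound 3 (1.59 log units; beyond the scatter).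

Compound 4 `Cc1ccc(CN2CCC(Cn3c(=O)oc4ccccc43)CC2)c(C)c1` is not yet measured. The change from compound 3 is 2,4-dimethylphenyl in place of 4-fluorophenyl on a saturated chain carbon bound to an amine nitrogen in a ring. Going by the values given here, two measured steps bear on it. The shift from a 4-substituted to a 2-substituted benzyl group was very costly, a 610-fold lower number from compound 1 to compound 2 (2.79 log units; beyond the scatter), and the change of the 4-substituent itself also moved the number strongly, a 39-fold higher number from compound 2 to compound 3 (1.59 log units; beyond the scatter). Compound 4 carries both a 2-methyl and a 4-methyl group, so one substituent sits at the position that hurt in compound 1 while the other sits where compounds 2 and 3 differ. Among the compounds with values here, no methyl analogue is measured, so the size of the 4-methyl contribution is unknown. The expected net step in this assay for compound 4 is therefore modest, a 2.1-fold higher number from compound 3 to compound 4 (0.31 log units; beyond the scatter), with wide uncertainty in both directions. Compound 4 is expected to give 8 nM, in the range 1.5 nM to 50 nM.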

Compound 4, inhibition constant: 30 nM
The estimate for compound 4 lay 3.8-fold (0.57 log units) below the measured number; the range from low to high includes it.
By their numbers in this assay, from the lowest: compound 2; then compound 3; then compound 4; then compound 1.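

In this assay, 2,4-dimethylphenyl on a saturated chain carbon bound to an amine nitrogen in a ring sits nearer to the 2-chlorophenyl group than to the 4-fluorophenyl or 4-chlorophenyl group, with a 2.0-fold lower number from compound 1 to compound 4 (0.31 log units; beyond the scatter), against a 7.7-fold higher number from compound 3 to compound 4 (0.89 log units; beyond the scatter) and a 300-fold higher number from compound 2 to compound 4 (2.48 log units; beyond the scatter). The two aryl groups with a substituent numbered 2, in compound 1 and compound 4, give the two highest numbers of the four, so the high number is no longer tied to 2-chlorophenyl alone, and the added methyl numbered 4 in compound 4 does not bring the number down to that of compound 3 or compound 2. No measurement at hand accounts for this order.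

How much of the step belongs to each methyl group stays open, since 2-methylphenyl and 4-methylphenyl are not among the compounds shown. Also open, on these data alone, is whether 2,4-dichlorophenyl would track compound 4 or compound 2, and where 4-bromophenyl or 4-methoxyphenyl would fall relative to compound 2 and compound 3.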